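Nitro to Chloro on the Aromatic Ring

A few compounds are considered here, and "the series" means these few. Any claim that something is new, unique, unknown or untested is made for them only; others in the source may bear on it.

Compound 1, `C/C(=C\c1cc(-c2ccc(C)cc2)cs1)C(N)=O`: > 50000 nM
Compound 2, `C/C(=C\c1cc(-c2ccc([N+](=O)[O-])cc2)cs1)C(N)=O`: 2380 nM

Both compounds were tested in a functional assay on HO8910 cells (Homo sapiens) for cytotoxicity, read by CCK-8 assay, with a stated time of 24 h; on this read-out higher numbers stand for weaker inhibition and lower numbers for stronger inhibition. For compound 1 the value > 50000 nM is a limit of the assay rather than a number (the limit of > 50000 nM in this assay, at which 1 of the 2 values shown sits). Going by the values given here, compound 2 gives 2380 nM, which is the only actual number in this set, so compound 2 stands as the one compound with a measured figure. Among the compounds with values here, the one measured step, an at least 21-fold lower number from compound 1 to compound 2 (1.32 log units; beyond the scatter), shows that changing the group at this place of the ring can shift the read-out strongly.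

Compound 3, `C/C(=C\c1cc(-c2ccc(Cl)cc2)cs1)C(N)=O`, differs from compound 2 by chloro in place of nitro on an aromatic carbon. Within the data shown here, no measured step covers chloro against nitro; the methyl-to-nitro step only shows that this place matters. Compound 3 is therefore expected to give about 15000 nM (range 3000 nM to 60000 nM). This means an expected step of a 6.3-fold higher number from compound 2 to compound 3 (0.80 log units; beyond the scatter), with a real chance that only a limit is reported.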

Compound 3, half-maximal inhibitory concentration: > 50000 nM
Compound 3: a limit, no number (the forecaster's own chance of this, stated with the estimate: 35%); middle value at least 3.3-fold (0.52 log units) from the limit.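

Replacing nitro with chloro gives an at least 21-fold higher number from compound 2 to compound 3 (1.32 log units; beyond the scatter) in this assay, so the measurable effect seen with compound 2 disappears with a second group, not only with methyl. Of the three groups shown on this aromatic carbon, para to a large group, only nitro gives an actual number, which makes compound 2 the exception in this small set. Compound 3 gives only a limit, as does compound 1, so the step between them cannot be read: the limit of > 50000 nM in this assay, at which 2 of the 3 values shown sit.

From the compounds shown here alone, how far compound 1 and compound 3 lie beyond that limit remains unknown. Going by these compounds, it is also open whether an amine, a carboxylic acid or a nitrile at this place would give a number like that of compound 2, or whether nitro stands alone.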